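The source may report more compounds than this note shows. Statements on the series, on what has been measured and on what is new or still open speak of the compounds shown alone.

Measured compounds in a functional assay on Jurkat cells for inhibition of nuclear factor NF-kappa-B complex (Homo sapiens); on this read-out higher numbers stand for weaker inhibition and lower numbers for stronger inhibition:
- compound 1 `CCOC(=O)c1cnc(-c2ccncc2)nc1NN1C(=O)C=C(C)C1=O`: 6000 nM
- compound 2 `CCOC(=O)c1cnc(-c2cccc([N+](=O)[O-])c2)nc1NN1C(=O)C=C(C)C1=O`: 7000 nM

Compound 2 gives the highest of the two numbers in this assay, and its nearest neighbour is compound 1, separated by a 1.2-fold higher number from compound 1 to compound 2 (0.07 log units; within the scatter); the two are therefore not distinguishable on this read-out.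

Compound 3 `CCOC(=O)c1cnc(-c2ccc(C)s2)nc1NN1C(=O)C=C(C)C1=O` is not yet measured. Relative to compound 2 the change is 5-methylthiophen-2-yl in place of 3-nitrophenyl on an aromatic carbon. Within the data shown here, the only measured step that bears on this position is the one from compound 1 to compound 2, in which one aromatic group was exchanged for another on the same carbon of the shared core and the number moved by a 1.2-fold higher number from compound 1 to compound 2 (0.07 log units; within the scatter). Both aromatic groups seen so far sit in the same narrow band, so a third aromatic group at this position is expected to give a number in the same band, with a step of a 1.2-fold lower number from compound 2 to compound 3 (0.07 log units; within the scatter) from compound 2 to compound 3 that is not expected to exceed the scatter. Among the measured compounds shown here, the single step available gives no basis for a direction. Compound 3 is therefore estimated at 6000 nM in this assay, within a range of 2500 nM to 15000 nM.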

Compound 3, half-maximal inhibitory concentration: 200 nM
For compound 3 the middle estimate is 30-fold (1.48 log units) above the measured one; measured number below the stated range.
By their numbers in this assay, from the lowest: compound 3; then compounds 1 and 2 (each within the scatter of the next).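

In this assay this position proves sensitive to the aromatic group it carries: on the shared core, 5-methylthiophen-2-yl in place of 3-nitrophenyl gives a 35-fold lower number from compound 2 to compound 3 (1.54 log units; beyond the scatter) and in place of pyridin-4-yl gives a 30-fold lower number from compound 1 to compound 3 (1.48 log units; beyond the scatter) at the same aromatic carbon. The exchange between the two six-membered aromatic rings, a 1.2-fold higher number from compound 1 to compound 2 (0.07 log units; within the scatter) and thus no distinguishable change, gave no sign of this, so the narrow band held by compound 1 and compound 2 does not describe the position as a whole. No measurement at hand accounts for a drop of this size.

Compound 3 brings in a five-membered aromatic ring, a sulfur atom and a methyl group in one change, and the compounds shown do not separate these features from one another. Still open, going by these compounds, are whether unsubstituted thiophen-2-yl, furan-2-yl or plain phenyl at this carbon keeps the lower number, and whether it survives replacing the ethoxycarbonyl group with a carboxylic acid or an amide.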